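The source may report more compounds than this note shows. Statements on the series, on what has been measured and on what is new or still open speak of the compounds shown alone.

Among the measured compounds shown here, compound 2 `CCO/C(O)=C1\C(COCCn2cc(C(N)=O)nn2)=NC(C)=C(C(=O)OC)C1c1ccccc1Cl` stands at the lowest of the two numbers so far: in a functional assay (aorta) with Rattus norvegicus as the target (on this read-out lower numbers stand for stronger inhibition and higher numbers for weaker inhibition), compound 2 gives 20 nM. Its nearest neighbour, compound 1 `CCOC(=O)c1cnnn1CCOCC1=NC(C)=C(C(=O)OC)C(c2ccccc2Cl)/C1=C(\O)OCC`, in this assay gives 100 nM, and the step of a 5.0-fold lower number from compound 1 to compound 2 (0.70 log units; beyond the scatter) is the only one recorded among the measured compounds. Compound 3 `CCO/C(O)=C1\C(COCCN2CC(=O)NC2=O)=NC(C)=C(C(=O)OC)C1c1ccccc1Cl` has not yet been measured in this assay. It differs from compound 2 in one place: 2,4-dioxoimidazolidin-1-yl in place of 4-carbamoyl-1H-1,2,3-triazol-1-yl on a saturated chain carbon, two bonds along the chain from an oxygen on a saturated carbon. The step from compound 1 to compound 2 bears only loosely on this change, since there the five-membered aromatic ring with 3 hetero atoms was kept and only the group on it was exchanged, whereas here the ring itself is replaced by a five-membered non-aromatic ring with 2 hetero atoms. With one step to go on, and that one at a different place, the size and direction of the new step are uncertain; the expectation for compound 3 is a number of similar size to that of compound 2 or somewhat higher, meaning a step of a 2.0-fold higher number from compound 2 to compound 3 (0.30 log units; within the scatter) that is expected to stay close to the scatter. In this assay compound 3 is therefore estimated at 40 nM, within a range from 10 nM to 160 nM.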

Compound 3, half-maximal inhibitory concentration: 20 nM
Compound 3: middle estimate off by 2.0-fold (0.30 log units), on the high side; measured number inside the range.
By their numbers in this assay, from the lowest: compounds 2 and 3 (each within the scatter of the next); then compound 1.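

In this assay, the exchange of 4-carbamoyl-1H-1,2,3-triazol-1-yl for 2,4-dioxoimidazolidin-1-yl gives no change at the digits printed from compound 2 to compound 3 (within the scatter), so on this saturated chain carbon, two bonds along the chain from an oxygen on a saturated carbon, a five-membered non-aromatic ring with 2 hetero atoms reads the same as a five-membered aromatic ring with 3 hetero atoms. The earlier step changed only the group carried on the aromatic ring, whereas this one shows that among these compounds the ring itself can be replaced without a change beyond the scatter. Measured against the ester-bearing triazole, the new ring gives a 5.0-fold lower number from compound 1 to compound 3 (0.70 log units; beyond the scatter), the same size as a 5.0-fold lower number from compound 1 to compound 2 (0.70 log units; beyond the scatter), so compound 1 stays apart from the other two. Nothing measured on these compounds bears on why the two rings read alike.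

As far as these compounds go, whether any ring is needed at this position remains open, since an open-chain urea or a simple primary amide on the same chain would be required to tell. Equally open, from the compounds shown here alone, is how a carboxylic acid on the triazole, or a longer chain carrying the 2,4-dioxoimidazolidin-1-yl group, would read.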